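The compounds below may be only part of what the source reports. "The series", "measured", "known", "first", "only" and "open" are said of these compounds alone.

Series notes. Compound 1 `Oc1ccc(-c2cc(-c3cccs3)nc(-c3ccccc3Cl)c2)cc1`, compound 2 `Oc1ccc(-c2cc(-c3ccncc3)nc(-c3ccc(Cl)cc3)c2)cc1` and compound 3 `Oc1ccc(-c2cc(-c3ccc(Cl)cc3)nc(-c3ccccn3)c2)cc1` share one core, the three varied aryl groups arranged around it. In a functional assay on T47D cells (Homo sapiens) for cytotoxicity, read by CCK-8 assay and cell counting, with a stated time of 2 days (a higher number here means a weaker inhibitor, a lower number a stronger inhibitor), compound 1 gives 5870 nM, compound 2 gives "not determined" (no result reported) and compound 3 gives 25900 nM. Of the two numbers shown, compound 3 holds the higher one and compound 1 the lower, a gap beyond the scatter. Compound 4 `Oc1ccc(-c2cc(-c3ccc(Cl)cc3)nc(-c3cccs3)c2)cc1` is unmeasured; it differs from compound 3 in one place: thiophen-2-yl in place of pyridin-2-yl on an aromatic carbon. The only thiophen-2-yl bearer measured, compound 1, sits at the lower number in this assay, so a step downward in number, modest in size and on the edge of the scatter, is expected as a 2.4-fold lower number from compound 3 to compound 4 (0.37 log units; beyond the scatter). Compound 4 is estimated at 11000 nM, between 4000 nM and 30000 nM.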

Compound 4, half-maximal inhibitory concentration: 6450 nM
Estimate against measurement, compound 4: 1.7-fold (0.23 log units) above, within the range that was stated.
By their numbers in this assay, from the lowest: compounds 1 and 4 (each within the scatter of the next); then compound 3.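

In this assay, among these compounds, thiophen-2-yl in place of pyridin-2-yl next to the ring nitrogen gives a 4.0-fold lower number from compound 3 to compound 4 (0.60 log units; beyond the scatter), the first direct reading of this change on the shared core. With thiophen-2-yl held, 4-chlorophenyl in place of 2-chlorophenyl gives a 1.1-fold higher number from compound 1 to compound 4 (0.04 log units; within the scatter), so the two chlorophenyl groups are not told apart here. No evidence on the cause of either step is at hand. On these data alone, whether an amine or a carboxylic acid at this position would keep the number of compound 4 stays open. So does whether the thiophen-2-yl step holds with other groups around the core.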